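The source may hold more compounds than are shown below. What is called first, only, known or untested is meant among the compounds shown, and "the series" means these compounds.

Measured compounds: compound 1 `Nc1cc(N)c2nc(-c3ccccc3)c(Oc3ccc(Cl)c(Cl)c3)nc2c1` gives 6030 nM; compound 2 `Nc1cc(N)c2nc(-c3ccccc3)c(Oc3ccc(F)cc3)nc2c1` gives 19100 nM; compound 3 `CCOC(=O)[C@H](CCC(=O)O)NC(=O)c1ccc(Oc2nc3cc(N)cc(N)c3nc2-c2ccccc2)cc1` gives 7410 nM.

In a functional assay on RXF 393 cells (Homo sapiens) for inhibition, read by sulforhodamine B assay, with a stated time of 48 h (a higher number here means a weaker inhibitor of growth, a lower number a stronger inhibitor of growth), compound 2 has the highest of the three numbers, with compound 3 nearest and compound 1 furthest. Compound 4 `Nc1cc(N)c2nc(-c3ccccc3)c(NCc3ccc(F)cc3)nc2c1` differs from compound 2 in one place: (4-fluorobenzyl)amino in place of 4-fluorophenoxy on an aromatic carbon. Going by the values given here, the only measured step, a 3.2-fold higher number from compound 1 to compound 2 (0.50 log units; beyond the scatter), changes the substituents on the aryl ring while keeping the oxygen link, so it does not bear directly on replacing that oxygen with a benzylamino link. Among the compounds with values here, no measured pair shows what such a change does here. Compound 4 is therefore expected to stay close to compound 2, with a step of a 1.3-fold lower number from compound 2 to compound 4 (0.10 log units; within the scatter) that could fall either way. The estimate for compound 4 is 15000 nM, expected to lie between 5000 nM and 45000 nM.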

Compound 4, concentration for 50% growth inhibition: 12300 nM
Estimate against measurement, compound 4: 1.2-fold (0.09 log units) above, within the range that was stated.
By their numbers in this assay, from the lowest: compounds 1, 3, 4 and 2 (each within the scatter of the next, the first and the last beyond it).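

In this assay, the step of a 1.6-fold lower number from compound 2 to compound 4 (0.19 log units; within the scatter) swaps the oxygen-linked 4-fluorophenoxy for (4-fluorobenzyl)amino and stays within the scatter, so this aromatic carbon tolerates that exchange without a readable change. The step of a 2.0-fold higher number from compound 1 to compound 4 (0.31 log units; beyond the scatter) is beyond the scatter but modest, and it alters the link and the ring substituents together, so their shares cannot be separated. Nothing at hand explains these numbers. Still open, going by these compounds, is what a (3,4-dichlorobenzyl)amino group, a simple amine or a longer chain would give at this carbon.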